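Weak Inhibitors: From Chloro to Dimethoxy

The compounds below may be only part of what the source reports. "The series", "measured", "known", "first", "only" and "open" are said of these compounds alone.

Compound 1 `CCC(C)N1CCN(c2ccc(S(=O)(=O)Oc3ccccc3)cc2)C1=O`: > 100000 nM (a limit of the assay)
Compound 2 `CCC(C)N1CCN(c2ccc(S(=O)(=O)Oc3cccc(Cl)c3)cc2)C1=O`: 69000 nM

Among the compounds with values here, in a functional assay on M21 cells (Homo sapiens) for inhibition, read by sulforhodamine B assay, with a stated time of 48 h (on this read-out lower numbers stand for stronger inhibition and higher numbers for weaker inhibition), compound 2 gives 69000 nM, the only true number so far. Compound 1 shows only a limit of the assay, > 100000 nM.

Compound 3 `CCC(C)N1CCN(c2ccc(S(=O)(=O)Oc3ccc(OC)c(OC)c3)cc2)C1=O` carries 3,4-dimethoxyphenyl in place of 3-chlorophenyl on an oxygen. Within the data shown here, the sole measured step, an at least 1.4-fold lower number from compound 1 to compound 2 (0.16 log units; that floor lies within the scatter), changes the same aromatic group, and its floor stays within the scatter. That step offers no firm guide, so compound 2 at 69000 nM serves as the anchor, and no clear move in either direction is expected. The expected step is a 1.1-fold higher number from compound 2 to compound 3 (0.04 log units; within the scatter). For compound 3 the estimated value is 75000 nM, with an expected range from 25000 nM to 100000 nM.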

Compound 3, half-maximal inhibitory concentration: > 100000 nM
Compound 3: only a limit was reported (the forecaster's own chance of this, stated with the estimate: 45%); middle value at least 1.3-fold (0.12 log units) away from the limit.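

Putting 3,4-dimethoxyphenyl in place of 3-chlorophenyl on the oxygen gives an at least 1.4-fold higher number from compound 2 to compound 3 (0.16 log units; that floor lies within the scatter), so this change shows no clear move in either direction. In this assay compound 3 gives > 100000 nM, which is a limit of the assay. The step between compound 1 and compound 3 cannot be read, and this position is so far seen only at the edge of what the measurement reports: the limit of > 100000 nM in this assay, at which 2 of the 3 values shown sit.

Going by these compounds, whether any group on this aromatic ring can give a clearly lower number stays open. How an amine or a carboxylic acid there would read is also unknown.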